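The compounds below may be only part of what the source reports. "The series", "measured", "known", "first", "only" and "open" are said of these compounds alone.

Measured so far in a functional assay on 786-0 cells (Homo sapiens) for antiproliferative activity, read by sulforhodamine B assay, with a stated time of 48 h; a higher number here means a weaker inhibitor of growth, a lower number a stronger inhibitor of growth:
compound 1 `CCCCCCCCCCCCCCCCCC(=O)N1CCOCC1` gives 41.1 ug/mL
compound 2 `CCCCCCCC/C=C\CCCCCCCC(=O)N1CCCC1` gives 5.2 ug/mL
compound 3 `CCCCCC[C@@H](O)C/C=C\CCCCCCCC(=O)N1CCOCC1` gives 36 ug/mL

Compound 1 holds the highest of the three numbers in this assay. Compound 3 sits within the scatter of compound 1, so the two cannot be ordered against each other. Compound 2 lies beyond the scatter and well under compound 1, but it differs from compound 1 in more than one place, so no single step can be read from that pair. Among the measured compounds shown here, no pair of measured compounds that differ in one place only is available.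

Compound 4 `CCCCCCCCCCCCCCCCCC(=O)N1CCCC1` keeps the chain of compound 1 and changes only the ring on the carbonyl carbon: pyrrolidin-1-yl in place of morpholin-4-yl on a carbonyl carbon. For the measured compounds named here, the two measured compounds that carry morpholin-4-yl, compound 1 and compound 3, sit at the high end of the range seen so far, and the one compound carrying pyrrolidin-1-yl, compound 2, sits at the low end. A step downward beyond the scatter is therefore expected, a 2.7-fold lower number from compound 1 to compound 4 (0.44 log units; beyond the scatter), with the caution that this rests on one compound whose chain also differs. Compound 4 is estimated at 15 ug/mL, with a range from 5 ug/mL to 45 ug/mL.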

Compound 4, concentration for 50% growth inhibition: 14 ug/mL
Compound 4: the middle estimate sits 1.1-fold (0.03 log units) above what was measured, within the range that was stated.
By their numbers in this assay, from the lowest: compound 2; then compound 4; then compounds 3 and 1 (each within the scatter of the next).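

In this assay, among the compounds shown here, compounds 1 and 4 give the first reading of this position with the chain held fixed. On a carbonyl carbon whose other neighbour is a saturated chain carbon, pyrrolidin-1-yl in place of morpholin-4-yl gives a 2.9-fold lower number from compound 1 to compound 4 (0.47 log units; beyond the scatter) as a modest step that stands clear of the scatter. The link between ring and growth inhibition, earlier suggested only by compounds with different chains, now rests on one matched pair, although no measurement on hand accounts for the step.

This single change alters ring size and removes the ring oxygen together, leaving their separate contributions unresolved; a piperidin-1-yl group on the same carbonyl carbon would keep the six-membered ring without that oxygen and help to tell them apart. Also open, going by these compounds, is whether the step holds on the chains of compound 2 and compound 3, and how an open-chain diethylamino group or a carboxylic acid in place of the ring would read in this assay on the chain of compound 1.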